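This account rests on a few compounds, and the source may have more. Where it says the series, first, only, none or still open, it means among the compounds named here.

The study follows a shared core measured in a functional assay on MCF7 cells (Homo sapiens) for antiproliferative activity, read by MTT assay, with a stated time of 72 h; on this read-out lower numbers stand for stronger inhibition and higher numbers for weaker inhibition. Compound 1 `COc1ccc2occ(CSC(=S)N3CCCCC3)c(=O)c2c1` carries a piperidin-1-yl group on the thiocarbonyl carbon. In this assay compound 1 gives only a limit, > 40000 nM, so no exact number for it is known (the limit of > 40000 nM in this assay, at which 1 of the 2 values shown sits). Compound 2 `COc1ccc2occ(CSC(=S)N3CCOCC3)c(=O)c2c1` carries morpholin-4-yl in place of piperidin-1-yl, and in this assay compound 2 gives 11800 nM; the change is an at least 3.3-fold lower number from compound 1 to compound 2 (0.53 log units; beyond the scatter). Compound 3 `O=c1c(CSC(=S)N2CCCCC2)coc2ccccc12` keeps the piperidin-1-yl group of compound 1 and differs from it in one place: hydrogen in place of methoxy on an aromatic carbon. Going by the values given here, no measured step touches this part of the core; the only measured step, from compound 1 to compound 2, concerns the group on the thiocarbonyl carbon and says nothing about the methoxy. Among the compounds with values here, compound 1 stands at the weak end of what has been measured, and with no guiding step, compound 3 is expected to remain at a similarly weak level, quite possibly again as a limit. The estimate for compound 3 is 50000 nM, within 15000 nM to 200000 nM, which would mean an expected step that the limit leaves unreadable from compound 1 to compound 3.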

Compound 3, half-maximal inhibitory concentration: 1700 nM
For compound 3 the middle estimate is 29-fold (1.47 log units) above the measured one; the measured number lies below the stated range.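

Going by these compounds alone, until this result, the only readable change lay on the thiocarbonyl carbon; the aromatic carbon that carries the methoxy now also proves to be a place where the read-out responds, since in this assay hydrogen in place of methoxy gives an at least 23-fold lower number from compound 1 to compound 3 (1.37 log units; beyond the scatter). As far as these compounds go, the true size of this step stays unknown and its figure is only a lower bound, because compound 1 gives a limit and not an exact number: the limit of > 40000 nM in this assay, at which 1 of the 3 values shown sits. Within the data shown here, with the piperidin-1-yl group kept, compound 3 also gives the first exact number for a compound carrying that group on the thiocarbonyl carbon, so later changes to that group can be read from a measured value.

From the compounds shown here alone, whether the change at this aromatic carbon depends on removing the methoxy itself, or whether another group there, such as fluorine, a hydroxyl or an amine, would give a similar number, remains open. It is also open how morpholin-4-yl behaves with hydrogen on that carbon, as the compounds shown carry morpholin-4-yl only together with the methoxy.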